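Bromophenyl Variant in a Thione Series

The compounds below may be only part of what the source reports. "The series", "measured", "known", "first", "only" and "open" are said of these compounds alone.

For the measured compounds named here, compound 1 `CCOc1ccccc1NCn1nc(-c2ccc3c(c2)OCCO3)oc1=S` is one of three compounds measured in a functional assay, with a stated time of 6 min; on this read-out lower numbers stand for stronger inhibition and higher numbers for weaker inhibition. In this assay compound 1 gives 5280 nM, the lowest of the three numbers, though its steps to the other two, a 1.4-fold higher number from compound 1 to compound 2 (0.14 log units; within the scatter) and a 1.4-fold higher number from compound 1 to compound 3 (0.14 log units; within the scatter), both stay within the scatter. Compound 2 `S=c1oc(-c2ccc3c(c2)OCCO3)nn1CNc1ccccc1Cl` gives 7230 nM in this assay, and compound 3 `S=c1oc(-c2ccc3c(c2)OCCO3)nn1CNc1ccc(Cl)cc1` gives 7270 nM; the step of a 1.0-fold higher number from compound 2 to compound 3 (0.00 log units; within the scatter) is likewise within the scatter. Compound 4 `S=c1oc(-c2ccc3c(c2)OCCO3)nn1CNc1cccc(Br)c1` remains unmeasured. It differs from compound 1 by 3-bromophenyl in place of 2-ethoxyphenyl on an amine nitrogen. The step from compound 1 to compound 3 bears most closely on this change, as it also replaces the 2-ethoxyphenyl with a halogen-bearing phenyl, and the step from compound 2 to compound 3 shows that 4-chlorophenyl in place of 2-chlorophenyl left the number unchanged. Going by the values given here, no step in this set exceeds the scatter, so no step beyond it is expected in this assay. Compound 4 is therefore estimated at 6500 nM, with a range from 3000 nM to 14000 nM. This corresponds to an expected 1.2-fold higher number from compound 1 to compound 4 (0.09 log units; within the scatter).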

Compound 4, half-maximal inhibitory concentration: 10800 nM
For compound 4 the middle estimate is 1.7-fold (0.22 log units) below the measured one; the range from low to high includes it.
By their numbers in this assay, from the lowest: compounds 1, 2, 3 and 4 (each within the scatter of the next, the first and the last beyond it).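

In this assay, for the compounds shown here, 3-bromophenyl in place of 2-ethoxyphenyl on an amine nitrogen gives a 2.0-fold higher number from compound 1 to compound 4 (0.31 log units; beyond the scatter) and is the only step in the set to pass the scatter, and only modestly. Against the two chlorophenyl compounds, the same place shows a 1.5-fold higher number from compound 3 to compound 4 (0.17 log units; within the scatter) and a 1.5-fold higher number from compound 2 to compound 4 (0.17 log units; within the scatter) and both stay within the scatter, so the three halogen-bearing phenyl groups cannot be told apart here. Going by these compounds alone, no evidence is at hand to explain the one step beyond the scatter.

Compounds 1 and 4 differ in both the substituent and where it sits on the phenyl, so a 3-ethoxyphenyl group would be needed to separate the two. From the compounds shown here alone, whether a carboxylic acid on that phenyl, or a saturated cyclohexyl group in its place, would move the number further remains open.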